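A few compounds are considered here, and "the series" means these few. Any claim that something is new, unique, unknown or untested is made for them only; others in the source may bear on it.

Compound 1 `O=C(CSc1snnc1-c1ccc(Br)cc1Br)Nc1ccccc1[N+](=O)[O-]` and compound 2 `Cc1cccc(C)c1NC(=O)CSc1snnc1-c1ccc(Br)cc1Br` share one core and differ only on the amide-type nitrogen, where compound 2 carries 2,6-dimethylphenyl in place of 2-nitrophenyl. In an ADME assay on MT4 cells (Homo sapiens) for cytotoxicity, read by MTT assay, with a stated time of 5 days (on this read-out lower numbers stand for higher toxicity in this test and higher numbers for lower toxicity in this test), compound 1 gives > 235000 nM, which is a limit of the assay rather than a number. In this assay compound 2 gives >= 198000 nM, again a limit and not a number. Among the compounds with values here, compound 2 thus stands only at a limit, and the single other value shown is a limit as well. The step that the two limits leave unreadable from compound 1 to compound 2 cannot be read in size or direction because both of its ends sit at the limits the limit of > 235000 nM in this assay, at which 1 of the 2 values shown sits, and (the limit of >= 198000 nM in this assay, at which 1 of the 2 values shown sits). Compound 3 `O=C(CSc1snnc1-c1ccc(Br)cc1Br)Nc1nccs1` is the next member of the series: 1,3-thiazol-2-yl in place of 2,6-dimethylphenyl on an amide-type nitrogen. Within the data shown here, only one measured step bears on this change, and it was unreadable, so no direction can be drawn from it. Compound 3 is therefore expected to remain near the same limit, with an estimate of 200000 nM and a range from 60000 nM to 300000 nM in this assay. The step that the limit leaves unreadable from compound 2 to compound 3 that this estimate means is expected to be none beyond the scatter.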

Compound 3, half-maximal cytotoxic concentration: 87800 nM
The estimate for compound 3 lay 2.3-fold (0.36 log units) above the measured number, within the range that was stated.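

In this assay, within the data shown here, the substituent on the amide-type nitrogen moves the read-out by a readable amount for the first time: 1,3-thiazol-2-yl in place of 2,6-dimethylphenyl gives an at least 2.2-fold lower number from compound 2 to compound 3 (0.35 log units; beyond the scatter), and 1,3-thiazol-2-yl in place of 2-nitrophenyl gives an at least 2.6-fold lower number from compound 1 to compound 3 (0.42 log units; beyond the scatter), so both changes point towards higher toxicity in this test. From the compounds shown here alone, compound 2 stands at a limit of the assay, so the full size of its step stays unknown: the limit of >= 198000 nM in this assay, at which 1 of the 3 values shown sits. Compound 1 also stands at a limit of the assay, and the same holds for its step: the limit of > 235000 nM in this assay, at which 1 of the 3 values shown sits.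

Going by these compounds, it remains open whether the lower number belongs to 1,3-thiazol-2-yl in particular or would also appear with another five-membered aromatic ring with hetero atoms, or simply with a smaller group in this place. On these data alone, it is also open how a pyridin-2-yl group, or a longer chain ending in a carboxylic acid or an amine, would read on the same amide-type nitrogen, and whether any such change would hold on a core other than the shared one.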